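This account rests on a few compounds, and the source may have more. Where it says the series, first, only, none or still open, it means among the compounds named here.

Measured compounds:
compound 1 `Cn1c(=O)c(=O)n(C2CCCC2)c2nc(N/N=C/c3ccccc3)ncc21` — > 100000 nM
compound 2 `Cc1cccc(/C=N/Nc2ncc3c(n2)n(C2CCCC2)c(=O)c(=O)n3C)c1` — 34500 nM
compound 3 `Cn1c(=O)c(=O)n(C2CCCC2)c2nc(N/N=C/c3ccc(O)c(F)c3)ncc21` — 97800 nM

In a functional assay on A549 cells (Homo sapiens) for antiproliferative activity, read by MTT assay (a lower number here means a stronger inhibitor, a higher number a weaker inhibitor), compound 1 stands only at a limit of the assay, > 100000 nM, with no number behind it. Compound 2 gives 34500 nM in this assay, and compound 3 gives 97800 nM. Of the measured steps, an at least 2.8-fold lower number from compound 1 to compound 2 (0.46 log units; beyond the scatter) is the one that speaks to the change followed here. The step of a 2.8-fold higher number from compound 2 to compound 3 (0.45 log units; beyond the scatter) runs the other way, and an at least 1.0-fold lower number from compound 1 to compound 3 (0.00 log units; that floor lies within the scatter) rests on the limit (the limit of > 100000 nM in this assay, at which 1 of the 3 values shown sits), so it tells little.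

The unmeasured compound 4 `Cc1cc(C)c(/C=N/Nc2ncc3c(n2)n(C2CCCC2)c(=O)c(=O)n3C)c(C)c1` differs from compound 1 in one place: 2,4,6-trimethylphenyl in place of phenyl on a carbon with a double bond to nitrogen. Because the step of an at least 2.8-fold lower number from compound 1 to compound 2 (0.46 log units; beyond the scatter) lowered the number with a single methyl, a lowering is expected for compound 4 as well, though with compound 1 at a limit the size is uncertain and a further limit cannot be ruled out. Compound 4 is expected to give about 30000 nM in this assay, within a range from 8000 nM to 100000 nM. The step expected is an at least 3.3-fold lower number from compound 1 to compound 4 (0.52 log units; beyond the scatter).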

Compound 4, half-maximal inhibitory concentration: 12000 nM
Compound 4: the middle estimate sits 2.5-fold (0.40 log units) above what was measured, within the range that was stated.
By their numbers in this assay, from the lowest: compound 4; then compound 2; then compound 3. At a limit, above all of these: compound 1.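

In this assay, 2,4,6-trimethylphenyl on the carbon with a double bond to nitrogen goes further than the 3-methylphenyl group, with a 2.9-fold lower number from compound 2 to compound 4 (0.46 log units; beyond the scatter), so the lowering seen with a single methyl was not the end of what this position allows. Against the 3-fluoro-4-hydroxyphenyl group the gain is larger, at an 8.2-fold lower number from compound 3 to compound 4 (0.91 log units; beyond the scatter), which makes compound 4 the lowest of the compounds with a number. The step of an at least 8.3-fold lower number from compound 1 to compound 4 (0.92 log units; beyond the scatter) gives only a floor, since compound 1 is a limit and not a number: the limit of > 100000 nM in this assay, at which 1 of the 4 values shown sits.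

The 3-methylphenyl and 2,4,6-trimethylphenyl groups differ in both the number and the places of their methyl groups, so the compounds shown do not separate the two. On these data alone, whether isopropyl, tert-butyl or dimethylamino on this ring would lower the number further stays open.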